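Ring size on the amide nitrogen and cytotoxicity

The source may hold more compounds than are shown below. What is called first, only, known or untested is meant among the compounds shown, and "the series" means these compounds.

Compound 1 `CC1CCCCC1N(CCCCCCN1C[C@H](O)[C@@H](O)[C@H](O)[C@H]1CO)C(=O)C(C)(C)C`: 310000 nM
Compound 2 `CC(C)(C)C(=O)N(CCCCCCN1C[C@H](O)[C@@H](O)[C@H](O)[C@H]1CO)C1CCCCCC1`: > 500000 nM

In an ADME assay on Huh-7 cells (Homo sapiens) for cytotoxicity, read by MTT assay (on this read-out lower numbers stand for higher toxicity in this test and higher numbers for lower toxicity in this test), compound 1 gives 310000 nM. For compound 2 the reading > 500000 nM is a limit of the assay, not a number (the limit of > 500000 nM in this assay, at which 1 of the 2 values shown sits). Going by the values given here, the only measured step that bears on the next change is an at least 1.6-fold higher number from compound 1 to compound 2 (0.20 log units; that floor lies within the scatter). Compound 3 `CC(C)(C)C(=O)N(CCCCCCN1C[C@H](O)[C@@H](O)[C@H](O)[C@H]1CO)C1CCCCCCC1` differs from compound 2 by cyclooctyl in place of cycloheptyl on an amide-type nitrogen. Compound 3 is expected to sit at or beyond the same limit, a change of a step that the limit leaves unreadable from compound 2 to compound 3. Compound 3 is therefore estimated at 550000 nM, with a range from 250000 nM to 1200000 nM.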

Compound 3, half-maximal cytotoxic concentration: 150000 nM
The estimate for compound 3 lay 3.7-fold (0.56 log units) above the measured number; the whole stated range lies above it.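

In this assay, going by these compounds alone, cyclooctyl in place of cycloheptyl on the amide-type nitrogen gives the first step at this position that lies beyond the scatter, an at least 3.3-fold lower number from compound 2 to compound 3 (0.52 log units; beyond the scatter). Compound 2 stands only as a limit of the assay, so that step is a floor: the limit of > 500000 nM in this assay, at which 1 of the 3 values shown sits. Cyclooctyl in place of 2-methylcyclohexyl also gives a 2.1-fold lower number from compound 1 to compound 3 (0.32 log units; beyond the scatter), which makes the eight-membered ring the most toxic of the three in this test.

Going by these compounds, whether a plain cyclohexyl or a cyclopentyl would fit this order stays open. So does the effect of an amine on the cyclooctyl ring.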